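The source may report more compounds than this note shows. Statements on the series, on what has been measured and on what is new or still open speak of the compounds shown alone.

Compound 1 `CCCn1c(=O)[nH]c2nc(-c3ccc(S(=O)(=O)N4CCN(Cc5cccc(Br)c5)CC4)cc3)[nH]c2c1=O` and compound 2 `CCCn1c(=O)[nH]c2nc(-c3ccc(S(=O)(=O)N4CCN(c5cccc(Br)c5)CC4)cc3)[nH]c2c1=O` share one core and differ only at an amine nitrogen in a ring. In an assay on CHO cells for displacement of a labelled ligand from adenosine receptor A2b (Homo sapiens), read by scintillation counting, with a stated time of 75 min, in the presence of a further agent that is not named here (on this read-out higher numbers stand for weaker inhibition and lower numbers for stronger inhibition), compound 1 gives 0.148 nM, and in this assay compound 2 gives 0.234 nM. On the numbers as written compound 2 sits at the larger of the two values, yet the step of a 1.6-fold higher number from compound 1 to compound 2 (0.20 log units; within the scatter) is within the scatter, so no ranking between them follows. Compound 3 `CCCn1c(=O)[nH]c2nc(-c3ccc(S(=O)(=O)N4CCN(c5ccccc5F)CC4)cc3)[nH]c2c1=O` has not yet been measured. It differs from compound 2 in one place: 2-fluorophenyl in place of 3-bromophenyl on an amine nitrogen in a ring. For the measured compounds named here, no measured step swaps one halogenated phenyl for another; the single step known here swaps a benzyl for a phenyl and is itself within the scatter. The step from compound 2 to compound 3 is therefore expected to be a 1.3-fold higher number from compound 2 to compound 3 (0.11 log units; within the scatter), not beyond the scatter. Compound 3 is estimated at 0.3 nM, with a range from 0.1 nM to 1 nM.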

Compound 3, inhibition constant: 3.22 nM
Estimate against measurement, compound 3: 11-fold (1.03 log units) below, and the stated range ends below it.
By their numbers in this assay, from the lowest: compounds 1 and 2 (each within the scatter of the next); then compound 3.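

This position, an amine nitrogen in a ring, is sensitive to what it carries: in this assay the change to 2-fluorophenyl gives a 14-fold higher number from compound 2 to compound 3 (1.14 log units; beyond the scatter) and also a 22-fold higher number from compound 1 to compound 3 (1.34 log units; beyond the scatter) on the same read-out, which means clearly weaker inhibition. The earlier step between 3-bromobenzyl and 3-bromophenyl stayed within the scatter, so a phenyl ring on this nitrogen does not by itself secure a low number. No measurement at hand accounts for this loss.

The new group differs from 3-bromophenyl in both its halogen and where that halogen sits, so the compounds shown cannot separate the two changes. A 3-fluorophenyl or a 2-bromophenyl group would pull them apart, and an unsubstituted phenyl would show what the halogen contributes at all.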